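Replacing the 2-methoxyphenyl group of compound 3

The source may report more compounds than this note shows. Statements on the series, on what has been measured and on what is new or still open speak of the compounds shown alone.

Values so far in a functional assay on K562 cells (Homo sapiens) for antiproliferative activity, read by MTT assay, with a stated time of 24 h; a lower number here means a stronger inhibitor, a higher number a weaker inhibitor
Compound 1 `COc1ccc(C(=O)/C=C/c2ccc(N(C)C)cc2)c2c1C=CC(C)(C)O2` gives 3500 nM
Compound 2 `COc1ccc(C(=O)/C=C/c2ccc([N+](=O)[O-])cc2)c2c1C=CC(C)(C)O2` gives 7770 nM
Compound 3 `COc1ccccc1/C=C/C(=O)c1ccc(OC)c2c1OC(C)(C)C=C2` gives > 10000 nM as a limit

In this assay compound 3 stands at > 10000 nM which is a limit and not a number. Compound 4 `COc1ccc(C(=O)/C=C/c2ccc(O)c(Br)c2)c2c1C=CC(C)(C)O2` carries 3-bromo-4-hydroxyphenyl in place of 2-methoxyphenyl (3-bromo-4-hydroxyphenyl in place of 2-methoxyphenyl on a double-bonded chain carbon bound to a double-bonded chain carbon) on a double-bonded chain carbon bound to a double-bonded chain carbon. Two measured steps end in the 2-methoxyphenyl group. From the compounds shown here alone, one is an at least 2.8-fold higher number from compound 1 to compound 3 (0.45 log units; beyond the scatter) and the other is an at least 1.2-fold higher number from compound 2 to compound 3 (0.10 log units; that floor lies within the scatter) so leaving that group is expected to lower the number, though the entering group is untested here. The two other groups themselves differ by a 2.2-fold higher number from compound 1 to compound 2 (0.35 log units; beyond the scatter) in this set. A modest step to a lower number is expected in this assay and is estimated as an at least 2.0-fold lower number from compound 3 to compound 4 (0.30 log units; that floor lies within the scatter) for now. For compound 4 the estimated value is 5000 nM with an expected range from 2000 nM to 12000 nM in this assay.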

Compound 4, half-maximal inhibitory concentration: > 10000 nM
Compound 4: only a limit was reported; the forecaster's own chance of this, stated with the estimate: 20%; at least 2.0-fold (0.30 log units) between middle value and limit.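

In this assay compound 4 gives > 10000 nM, which is a limit and not a number. With 3-bromo-4-hydroxyphenyl in place of 2-methoxyphenyl, the step between the two compounds cannot be read: the limit of > 10000 nM in this assay, at which 2 of the 4 values shown sit.

Set against the other groups at this position, the same change gives an at least 2.8-fold higher number from compound 1 to compound 4 (0.45 log units; beyond the scatter) and an at least 1.2-fold higher number from compound 2 to compound 4 (0.10 log units; that floor lies within the scatter).

The compounds shown leave open whether the bromine or the hydroxyl of the entering group matters more. From the compounds shown here alone, how a carboxylic acid or a primary amine would read at this position also remains open.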